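A few compounds are considered here, and "the series" means these few. Any claim that something is new, unique, unknown or untested is made for them only; others in the source may bear on it.

Measured so far:
compound 1, `O=C(NO)c1ccc(NCc2nc(-c3ccco3)nn2-c2ccccc2)cc1`: in an assay on Sf9 cells for inhibition of protein deacetylase HDAC6 (Homo sapiens), read by fluorescence, with a stated time of 40 min, tested at 100 nM (a lower number here means less inhibition, a higher number more inhibition at the concentration tested (going by the name of the read-out)), compound 1 gives 59.9%
compound 2, `O=C(NO)c1ccc(NCc2nc(-c3ccccn3)nn2-c2ccccc2)cc1`: in this assay compound 2 gives 58.6%

Going by the values given here, compound 2 holds the lower of the two numbers, but its only neighbour is compound 1, and the step of a number 1.3 percentage points lower from compound 1 to compound 2 (within the scatter) lies within the scatter, so the two compounds cannot be told apart on these data.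

Compound 3, `O=C(NO)c1ccc(NCc2nc(-c3ccncc3)nn2-c2ccccc2)cc1`, is not yet measured. Its change from compound 2 is pyridin-4-yl in place of pyridin-2-yl on an aromatic carbon. Among the compounds with values here, the single measured step, a number 1.3 percentage points lower from compound 1 to compound 2 (within the scatter), exchanged furan-2-yl for pyridin-2-yl on the same aromatic carbon of the shared core and moved the read-out only within the scatter; it bears on compound 3 only loosely, as no measured step exchanges one pyridinyl for another. No change at this carbon has yet shifted this assay beyond the scatter, and nothing in the data points in either direction. The expected step of a number 1.6 percentage points lower from compound 2 to compound 3 (within the scatter) is therefore no change beyond the scatter. Compound 3 is expected to give 57% in this assay, with a range from 40% to 72%.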

Compound 3, a percentage reported as inhibition, at one concentration (the size of the read-out at that concentration, not a potency): 30.8%
Estimate against measurement, compound 3: 26.2 percentage points above; measured number below the stated range.
By their numbers in this assay, from the lowest: compound 3; then compounds 2 and 1 (each within the scatter of the next).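

This aromatic carbon of the five-membered ring with 3 nitrogen is now shown to be sensitive in this assay, since exchanging one pyridinyl isomer for another, with the same atoms in the group, gives a number 27.8 percentage points lower from compound 2 to compound 3 (beyond the scatter) in the series. Replacing furan-2-yl with pyridin-4-yl gives a number 29.1 percentage points lower from compound 1 to compound 3 (beyond the scatter) as well, while the replacement with pyridin-2-yl gave only a number 1.3 percentage points lower from compound 1 to compound 2 (within the scatter), so among the three compounds the read-out follows the particular pyridinyl isomer and not the mere presence of a pyridine ring. The data at hand give no measurement that accounts for the gap between the two pyridinyl groups.

Pyridin-3-yl would show whether the read-out changes gradually across the pyridinyl isomers or whether pyridin-4-yl stands alone, and a plain phenyl group or an aminophenyl group at the same carbon would show whether the pyridin-4-yl result depends on the ring nitrogen at all. As far as these compounds go, these are readings at a single concentration, so how far the step from compound 2 to compound 3 reflects a difference in potency also stays open.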